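This account rests on a few compounds, and the source may have more. Where it says the series, first, only, none or still open, it means among the compounds named here.

In an ADME assay on BJ cells (Homo sapiens) for cytotoxicity, with a stated time of 72 h (a higher number here means that more compound is needed for the effect, a lower number that less compound is needed), compound 1 `CCOC(=O)CNc1nc(-n2nc(-c3ccccn3)nc2N)c2cc(OC)c(OC)cc2n1` gives > 27000 nM, which is a limit. Compound 2 `COc1cc2nc(C)nc(-n3nc(-c4ccccn4)nc3N)c2cc1OC` gives > 13000 nM, also a limit. Compound 3 `COc1cc2nc(-c3ccccc3)nc(-n3nc(-c4ccccn4)nc3N)c2cc1OC` gives > 27000 nM, again a limit, so it stands in the series without a numerical reading.

Compound 4 `COc1cc2nc(N)nc(-n3nc(-c4ccccn4)nc3N)c2cc1OC` keeps the shared core of compound 3 and differs by amino in place of phenyl on an aromatic carbon. In words, amino takes the place of phenyl on an aromatic carbon, between two ring nitrogen atoms.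

Three measured changes at this same place bear on it: a step that the two limits leave unreadable from compound 1 to compound 2, a step that the two limits leave unreadable from compound 1 to compound 3 and a step that the two limits leave unreadable from compound 2 to compound 3. None of them has a readable size, and compounds 1, 2 and 3 all end in limits, so the series offers no measured effect of this place to carry over. No step beyond the scatter is therefore expected in this assay, and no direction can be assigned. The expected step is an at least 1.0-fold lower number from compound 3 to compound 4 (0.03 log units; that floor lies within the scatter). A further limit is the most likely report for compound 4. For compound 4 the estimated value is 25000 nM, with an expected range of 8000 nM to 50000 nM.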

Compound 4, half-maximal effective concentration: > 27000 nM
Compound 4: only a limit was reported (the forecaster's own chance of this, stated with the estimate: 80%); middle value at least 1.0-fold (0.03 log units) away from the limit.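

In this assay, within the data shown here, compound 4 gives > 27000 nM, a limit, so no step to compound 4 from compound 1, compound 2 or compound 3 can be read. The compounds shown leave open whether the group at this place changes the half-maximal effective concentration at all, as all four values are limits.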